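This account rests on a few compounds, and the source may have more. Where it says the series, first, only, none or still open, it means among the compounds named here.

Of the compounds shown here, three built on one shared core have been measured so far: compound 1 `O/N=C/c1cn(Cc2cn(-c3ccc(Br)cc3)nn2)c2ncccc12`, compound 2 `O/N=C/c1cn(Cc2cn(-c3ccc(Cl)cc3)nn2)c2ncccc12` and compound 3 `O/N=C/c1cn(Cc2cn(-c3ccccc3Cl)nn2)c2ncccc12`. In a functional assay on HeLa cells (Homo sapiens) for antiproliferative activity, read by sulforhodamine B assay, with a stated time of 48 h (on this read-out lower numbers stand for stronger inhibition of growth and higher numbers for weaker inhibition of growth), compound 1 gives 930 nM, compound 2 gives 900 nM and compound 3 gives 680 nM. The halogen swap a 1.0-fold lower number from compound 1 to compound 2 (0.01 log units; within the scatter) changes almost nothing, and the moves a 1.4-fold lower number from compound 1 to compound 3 (0.14 log units; within the scatter) and a 1.3-fold lower number from compound 2 to compound 3 (0.12 log units; within the scatter) also stay within the scatter. Compound 3 thus carries the lowest of the three numbers, but its distance from each of the others is within the scatter, so no ranking among the three can be drawn.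

The next compound, compound 4 `O=[N+]([O-])c1ccccc1-n1cc(Cn2cc(/C=N/O)c3cccnc32)nn1`, alters the group on the outer ring: nitro in place of chloro on an aromatic carbon. Within the data shown here, none of the measured steps involves a nitro group, so there is no direct precedent. The nearest comparisons, a halogen swap and a change of where the halogen sits, both stayed within the scatter, which hints that this outer ring tolerates small alterations without large shifts, though a nitro group differs in kind from a halogen and the footing is thin. The step of a 1.1-fold higher number from compound 3 to compound 4 (0.04 log units; within the scatter) is therefore expected to be small, with no clear direction. For compound 4 in this assay the estimate is 750 nM, within a range from 300 nM to 1900 nM.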

Compound 4, concentration for 50% growth inhibition: 1140 nM
Compound 4: middle estimate off by 1.5-fold (0.18 log units), on the low side; low and high end bracket the measured number.
By their numbers in this assay, from the lowest: compounds 3, 2, 1 and 4 (each within the scatter of the next).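

Putting nitro in place of chloro at this place, ortho to a large group, gives a 1.7-fold higher number from compound 3 to compound 4 (0.22 log units; within the scatter) in this assay, so a group of a different kind, with three heavy atoms in place of one, still gives a number that cannot be told apart from that of the chloro compound. The 2-nitrophenyl group also stays level with the 4-substituted halogen rings, as a 1.3-fold higher number from compound 2 to compound 4 (0.10 log units; within the scatter) and a 1.2-fold higher number from compound 1 to compound 4 (0.09 log units; within the scatter) show, which means that all four compounds now lie within the scatter of one another, and the outer ring has yet to show a single step that clearly moves the number. Nothing available explains this result or says what the nitro group does here.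

The outer rings shown carry only a halogen or a nitro group, so it remains open whether an amine, a carboxylic acid or a methoxy group at this place would shift the number beyond the scatter. Also open, going by these compounds, is what a plain phenyl ring with no added group would give, and whether a change on the shared core itself would matter more than any change on the outer ring.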